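The compounds below may be only part of what the source reports. "The series", "measured", "known", "first", "only" and "open" are said of these compounds alone.

Measured compounds and their values:
- compound 1, `Cc1ccc(-n2cc(CNC(=O)c3cccc4c3cnn4C(C)C)nn2)c(C)c1`, > 40000 nM (a limit)
- compound 2, `CC(C)n1ncc2c(C(=O)NCc3cn(-c4ccc(F)cc4)nn3)cccc21`, > 40000 nM (a limit)
- compound 3, `CC(C)n1ncc2c(C(=O)NCc3cn(-c4cccc(F)c4)nn3)cccc21`, > 40000 nM (a limit)

In a functional assay on MCF7 cells (Homo sapiens) for inhibition, read by MTT assay, with a stated time of 72 h (on this read-out lower numbers stand for stronger inhibition and higher numbers for weaker inhibition), compound 3 gives only the limit > 40000 nM, and no number. Compound 1 also sits at a limit, > 40000 nM. Compound 2 likewise sits at a limit, > 40000 nM. All three values rest on the same limit, as the limit of > 40000 nM in this assay, at which 3 of the 3 values shown sit, shows, so the steps a step that the two limits leave unreadable from compound 1 to compound 2, a step that the two limits leave unreadable from compound 1 to compound 3 and a step that the two limits leave unreadable from compound 2 to compound 3 cannot be read. Compound 4, `Cc1ccccc1-n1cc(CNC(=O)c2cccc3c2cnn3C(C)C)nn1`, differs from compound 3 by 2-methylphenyl in place of 3-fluorophenyl on an aromatic nitrogen. Going by the values given here, no measured step bears readably on this change, and the three changes of the ring on the aromatic nitrogen so far all left the compounds at the limit. Compound 4 is therefore expected to sit at the limit as well, estimated at 40000 nM with a range from 20000 nM to 80000 nM, a step of a number no higher from compound 3 to compound 4 (the limit leaves the size open) expected.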

Compound 4, half-maximal inhibitory concentration: > 40000 nM
Compound 4 was reported as a limit; the forecaster's own chance of this, stated with the estimate: 85%; the middle value lies on the limit itself.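

In this assay, going by these compounds alone, no step to compound 4 from compound 1, compound 2 or compound 3 can be read, since all four values are limits: the limit of > 40000 nM in this assay, at which 4 of the 4 values shown sit.
Going by these compounds, how strongly any of these four compounds inhibits, and whether the ring on the aromatic nitrogen matters at all, stays open.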